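The source may report more compounds than this note shows. Statements on the series, on what has been measured and on what is new or still open speak of the compounds shown alone.

Compound 1 `O=C1NCCN1CCCCN1CCC(c2cn(-c3ccc(F)cc3)c3ccc(Cl)cc23)CC1` opens the account. In a functional assay on the whole organism for inhibition, with Rattus norvegicus as the target (on this read-out higher numbers stand for an effect only at larger amounts of compound and lower numbers for an effect already at smaller amounts), compound 1 gives > 2.2 umol/kg, and this is a limit of the assay rather than a measured number, so compound 1 stands only at a bound the limit of > 2.2 umol/kg in this assay, at which 1 of the 3 values shown sits, and cannot be placed against the others with certainty. Compound 2 `O=C1NCCN1CCN1CCC(c2cn(-c3ccc(F)cc3)c3ccc(C(F)(F)F)cc23)CC1` gives 0.11 umol/kg in this assay. Compound 3 `O=C1NCCN1CCN1CC=C(c2cn(-c3ccc(F)cc3)c3ccc(C(F)(F)F)cc23)CC1` gives > 0.66 umol/kg in this assay, again a limit and not a number (the limit of > 0.66 umol/kg in this assay, at which 1 of the 3 values shown sits). Compound 4 `O=C1N(CCN2CCC(c3cn(-c4ccc(F)cc4)c4ccc(Cl)cc34)CC2)CCN1c1ccccc1` differs from compound 1 in one place: 2-oxo-3-phenylimidazolidin-1-yl in place of 2-(2-oxoimidazolidin-1-yl)ethyl on a saturated chain carbon, two bonds along the chain from an amine nitrogen in a ring. Within the data shown here, no step between two measured compounds has been worked out in this set, so the size of the move from compound 1 onward rests on expectation alone. The shorter chain of compound 4 resembles that of compound 2, whose value of 0.11 umol/kg is a number and not a limit. The expected step is an at least 4.4-fold lower number from compound 1 to compound 4 (0.64 log units; beyond the scatter), toward an effect at smaller amounts, though a further limit remains possible. Compound 4 is estimated at 0.5 umol/kg, with a range from 0.1 umol/kg to 2.5 umol/kg.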

Compound 4, dose for half-maximal effect: > 0.15 umol/kg
Compound 4 ended at the assay's limit (the forecaster's own chance of this, stated with the estimate: 35%); the middle value lies beyond the limit too.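

Compound 4 gives > 0.15 umol/kg in this assay, a limit and not a number. Compound 1 also stands at a limit, so no step can be read between compound 1 and compound 4. The compounds shown leave open how far 2-oxo-3-phenylimidazolidin-1-yl shifts the dose relative to 2-(2-oxoimidazolidin-1-yl)ethyl.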